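The compounds below may be only part of what the source reports. "The series", "measured", "known", "first", "only" and "open" are said of these compounds alone.

For the measured compounds named here, in a functional assay on cells (Homo sapiens) for antiproliferative activity, read by MTT assay, with a stated time of 48 h (a lower number here means a stronger inhibitor, a higher number a weaker inhibitor), compound 1 (`CCN(CC)CCCn1c(N)c(-c2nc3ccccc3[nH]2)c2nc(C#N)c(C#N)nc21`) gives 28900 nM and stands highest of the two numbers measured so far, while compound 2 (`CCN(CC)CCCCn1c(N)c(-c2nc3ccccc3[nH]2)c2nc(C#N)c(C#N)nc21`) gives 640 nM as the lower one. Compound 3 (`CCN(CC)CCCn1c(N)c(-c2nc3ccccc3n2C)c2nc(C#N)c(C#N)nc21`) keeps the chain of compound 1 and carries methyl in place of hydrogen on an aromatic nitrogen. Going by the values given here, the only measured step (a 45-fold lower number from compound 1 to compound 2 (1.65 log units; beyond the scatter)) is large but lies on the chain, so it bears little on this change. A modest shift toward a lower number is expected, though the direction is uncertain. The estimated step is a 1.9-fold lower number from compound 1 to compound 3 (0.28 log units; within the scatter) and no more. For compound 3 the expected value is 15000 nM with an estimated range from 3000 nM to 60000 nM overall.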

Compound 3, half-maximal inhibitory concentration: 6750 nM
Beside the measured number, compound 3's estimate is 2.2-fold (0.35 log units) above it; low and high end bracket the measured number.
By their numbers in this assay, from the lowest: compound 2; then compound 3; then compound 1.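

In this assay, for the compounds shown here, methyl on the aromatic nitrogen gives a 4.3-fold lower number from compound 1 to compound 3 (0.63 log units; beyond the scatter) and so provides the first measured step at this position, away from the chain. Hydrogen on this nitrogen is therefore not needed for the lower number seen with compound 3. Nothing available here accounts for the size or direction of this step. Still open, from the compounds shown here alone, is whether ethyl or benzyl on this nitrogen would lower the number further. Also open, going by these compounds, is whether methyl would give a similar step on the longer chain of compound 2.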